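The compounds below may be only part of what the source reports. "The series", "measured", "known", "first", "only" and "open" are said of these compounds alone.

Compound 1 `N#C[C@]1(O)[C@H](O)[C@@H](CO)O[C@@H](n2cc(F)c(O)nc2=O)[C@@H]1O` and compound 3 `N#C[C@H]1[C@@H](O)[C@H](n2cc(F)c(O)nc2=O)O[C@H](CO)[C@H]1O` are built on different cores; the difference between the two cores is not broken down here. In a functional assay on L1210 cells (Mus musculus) (a lower number here means a stronger inhibitor, a higher number a weaker inhibitor), compound 1 gives 1900 nM, while compound 3 gives 550000 nM. Compound 2 `N#C[C@]1(O)[C@H](O)[C@@H](CO)O[C@@H](n2ccc(O)nc2=O)[C@@H]1O` comes from compound 1 by one change, (hydrogen in place of fluoro on an aromatic carbon), and in this assay compound 2 gives 417000 nM, so that a 220-fold higher number from compound 1 to compound 2 (2.34 log units; beyond the scatter). Compound 4 `N#C[C@H]1[C@@H](O)[C@H](n2ccc(O)nc2=O)O[C@H](CO)[C@H]1O` comes from compound 3 by the same change, (hydrogen in place of fluoro on an aromatic carbon), made on the core of compound 3. Among the compounds with values here, because compound 3 already gives 550000 nM, the expected step of a 3.6-fold higher number from compound 3 to compound 4 (0.56 log units; beyond the scatter) is smaller than the one seen from compound 1, as the read-out is expected to reach the edge of what this assay can report. For compound 4 the estimate in this assay is 2000000 nM, within 500000 nM to 20000000 nM.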

Compound 4, half-maximal inhibitory concentration: > 500000 nM
Compound 4 ended at the assay's limit; the forecaster's own chance of this, stated with the estimate: 50%; the middle value does not contradict the limit.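

The step from compound 3 to compound 4 cannot be read, as compound 4 gives a limit of the assay and not a number: the limit of > 500000 nM in this assay, at which 1 of the 4 values shown sits.

The compounds shown leave open whether hydrogen in place of fluoro changes the read-out as much on the core of compound 3 as on the core of compound 1.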